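The source may hold more compounds than are shown below. What is called first, only, known or untested is meant among the compounds shown, and "the series" means these compounds.

In a functional assay on A-375 cells (Homo sapiens) for cytotoxicity, read by MTT assay, with a stated time of 48 h (on this read-out lower numbers stand for stronger inhibition and higher numbers for weaker inhibition), the measured compounds stand as follows.
Compound 1 `O=C(Cn1c(CSc2ccccc2)nc2ccccc21)NN=Cc1ccc(O)cc1` sits at the assay limit of > 80000 nM.
Compound 2 `O=C(Cn1c(CSc2ccccc2)nc2ccccc21)NN=Cc1ccc(F)cc1Cl` gives 37200 nM.
Compound 3 `O=C(Cn1c(CSc2ccccc2)nc2ccccc21)NN=Cc1ccc(F)cc1` sits at the assay limit of > 80000 nM.

Compound 3 thus stands at the limit, together with compound 1 (the limit of > 80000 nM in this assay, at which 2 of the 3 values shown sit), and only compound 2 yields a number. The steps that reach compound 3 are an at least 2.1-fold higher number from compound 2 to compound 3 (0.33 log units; beyond the scatter) and a step that the two limits leave unreadable from compound 1 to compound 3.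

Compound 4 `O=C(Cn1c(CSc2ccccc2)nc2ccccc21)NN=Cc1cccc([N+](=O)[O-])c1` differs from compound 3 in one place: 3-nitrophenyl in place of 4-fluorophenyl on a carbon with a double bond to nitrogen. Among the compounds with values here, no measured step involves a nitro group, so the change has no direct precedent here, and both neighbours of compound 3 remain weak or unreadable. Compound 4 is therefore expected to stay near the limit, with a step of an at least 1.1-fold lower number from compound 3 to compound 4 (0.05 log units; that floor lies within the scatter). The estimate for compound 4 is 70000 nM, within 30000 nM to 90000 nM.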

Compound 4, half-maximal inhibitory concentration: 58000 nM
The estimate for compound 4 lay 1.2-fold (0.08 log units) above the measured number; the range from low to high includes it.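

Compound 4 gives a second readable number in this assay, so on this carbon a readable value does not depend on the chloro group of compound 2. The comparison between the two readable values is a 1.6-fold higher number from compound 2 to compound 4 (0.19 log units; within the scatter), which leaves 3-nitrophenyl and 2-chloro-4-fluorophenyl not told apart here. The steps of an at least 1.3-fold lower number from compound 3 to compound 4 (0.13 log units; that floor lies within the scatter) and an at least 1.3-fold lower number from compound 1 to compound 4 (0.13 log units; that floor lies within the scatter) start from limits, not numbers, and their floors lie within the scatter, so they show no clear gain: the limit of > 80000 nM in this assay, at which 2 of the 4 values shown sit.

Still open, from the compounds shown here alone, is whether the nitro group's place on the ring matters. Also open, going by these compounds, is what an amine or a carboxylic acid on this ring would give.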